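Amide nitrogen substituent: ring replaced by sec-butyl chain

The source may hold more compounds than are shown below. What is called first, only, known or untested is meant among the compounds shown, and "the series" means these compounds.

Three compounds of the shared core have been run in an assay on HEK293 cells for agonist activity at transient receptor potential cation channel subfamily M member 8 (Homo sapiens), read by fluorescence and calcium flux, with a stated time of 15 min; a lower number here means that less compound is needed, a higher number that more compound is needed for the effect:

compound 1 `Cc1ccc(OCC(=O)N(Cc2cccs2)c2cccnc2)cc1`: 198 nM
compound 2 `Cc1ccc(OCC(=O)N(Cc2cccs2)c2ccn(C)n2)cc1`: 855 nM
compound 3 `Cc1ccc(OCC(=O)N(Cc2cccs2)c2ccccn2)cc1`: 200 nM

Compound 3 stands second highest of the three numbers. Its value is level with that of compound 1, as a 1.0-fold higher number from compound 1 to compound 3 (0.00 log units; within the scatter), so swapping pyridin-2-yl for pyridin-3-yl on the amide-type nitrogen makes no difference here. Against that, a 4.3-fold lower number from compound 2 to compound 3 (0.63 log units; beyond the scatter) and a 4.3-fold higher number from compound 1 to compound 2 (0.64 log units; beyond the scatter) show that exchanging either pyridinyl for 1-methyl-1H-pyrazol-3-yl costs a modest step.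

Compound 4 `CCC(C)N(Cc1cccs1)C(=O)COc1ccc(C)cc1` goes further: sec-butyl in place of pyridin-2-yl on an amide-type nitrogen. Within the data shown here, no measured step removes the ring altogether, so the bearing steps are indirect. They show that the identity of the group on the amide-type nitrogen matters by up to a modest step, and a change from a ring to a chain is larger than any of them. A step beyond the scatter toward a higher number is therefore expected, a 4.5-fold higher number from compound 3 to compound 4 (0.65 log units; beyond the scatter), with wide uncertainty. Compound 4 is estimated at 900 nM, with a range from 250 nM to 4000 nM.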

Compound 4, half-maximal effective concentration: 2000 nM
Beside the measured number, compound 4's estimate is 2.2-fold (0.35 log units) below it, within the range that was stated.
By their numbers in this assay, from the lowest: compounds 1 and 3 (each within the scatter of the next); then compound 2; then compound 4.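

In this assay, among these compounds, replacing a ring on the amide-type nitrogen with sec-butyl gives the largest steps at this position so far, both from pyridin-2-yl (a 10-fold higher number from compound 3 to compound 4 (1.00 log units; beyond the scatter)) and from pyridin-3-yl (a 10-fold higher number from compound 1 to compound 4 (1.00 log units; beyond the scatter)). The step from the 1-methyl-1H-pyrazol-3-yl compound (a 2.3-fold higher number from compound 2 to compound 4 (0.37 log units; beyond the scatter)) is also beyond the scatter, so among these four compounds the only one without a ring at this place has the highest number. The data available give no explanation for this result.

On these data alone, it remains open whether the rise follows from losing the ring or is specific to sec-butyl. Cyclohexyl, phenyl or a longer chain such as n-hexyl on the same nitrogen would help to separate the two.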